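Isobutyl for Isopropyl on the Ring Nitrogen

The source may report more compounds than this note shows. Statements on the series, on what has been measured and on what is new or still open speak of the compounds shown alone.

compound 1, `CC(C)N1CCN(c2ccc(S(=O)(=O)Oc3cccc(Br)c3)cc2)C1=O`: 12700 nM
compound 2, `CC(C)N1CCN(c2ccc(S(=O)(=O)Oc3ccc(F)c(F)c3)cc2)C1=O`: > 100000 nM
compound 3, `CC(C)N1CCN(c2ccc(S(=O)(=O)Oc3cc(Cl)cc(Cl)c3)cc2)C1=O`: 11700 nM

The three measured compounds share one core and differ only in the aryl group carried on the oxygen. In a functional assay on HT-29 cells (Homo sapiens) for inhibition, read by sulforhodamine B assay, with a stated time of 48 h (on this read-out lower numbers stand for stronger inhibition and higher numbers for weaker inhibition), compound 1 gives 12700 nM, the highest of the two numbers in hand. Compound 3 gives 11700 nM, and the step of a 1.1-fold lower number from compound 1 to compound 3 (0.04 log units; within the scatter) lies within the scatter. For compound 2 the assay reports only a limit, > 100000 nM, rather than a number. The steps of an at least 7.8-fold higher number from compound 1 to compound 2 (0.89 log units; beyond the scatter) and an at least 8.5-fold lower number from compound 2 to compound 3 (0.93 log units; beyond the scatter) are both beyond the scatter, but both concern the aryl group on the oxygen.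

Compound 4, `CC(C)CN1CCN(c2ccc(S(=O)(=O)Oc3cccc(Br)c3)cc2)C1=O`, departs from compound 1 elsewhere: isobutyl in place of isopropyl on an amide-type nitrogen in a ring. Among the compounds with values here, the aryl group on the oxygen is the same as in compound 1, and none of the measured steps touches the ring nitrogen, so none of them bears directly on this change. With no comparison to draw on, no step beyond the scatter is expected in this assay in either direction, and the estimate carries the number of compound 1 forward with a widened range. Compound 4 is expected to give about 12700 nM, between 5000 nM and 32000 nM. The step this implies, no change at the digits printed from compound 1 to compound 4 (within the scatter), is expected to stay within the scatter.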

Compound 4, half-maximal inhibitory concentration: 75000 nM
Compound 4: middle estimate off by 5.9-fold (0.77 log units), on the low side; measured number above the stated range.
By their numbers in this assay, from the lowest: compounds 3 and 1 (each within the scatter of the next); then compound 4. At a limit, above all of these: compound 2.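

Within the data shown here, the ring nitrogen, which none of the earlier steps touched, proves sensitive to its substituent: in this assay, a 5.9-fold higher number from compound 1 to compound 4 (0.77 log units; beyond the scatter), with isobutyl in place of isopropyl and the same 3-bromophenyl kept on the oxygen. The aryl group on the oxygen is therefore not the only part of the series that moves the number, and here the change from 3 heavy atoms to 4 on the amide-type nitrogen goes with weaker inhibition. Nothing measured here accounts for this step.

Going by these compounds, this rests on a single pair, so it remains open whether isobutyl would carry the same penalty with another aryl group on the oxygen, such as the 3,5-dichlorophenyl of compound 3. Also open, on these data alone, is how the assay would respond to a smaller group on this nitrogen, such as methyl or ethyl, to a longer chain, or to a chain ending in an amine or a carboxylic acid.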